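This account rests on a few compounds, and the source may have more. Where it says the series, first, only, none or still open, it means among the compounds named here.

Compound 1 `Nc1ccc(S(=O)(=O)N2CCN(c3ncc(C(O)(C(F)(F)F)C(F)(F)F)cc3-c3ccoc3)CC2)cn1`: < 14 mL.min-1.g-1
Compound 2 `CS(=O)(=O)Nc1cccc(-c2cc(C(O)(C(F)(F)F)C(F)(F)F)cnc2N2CCN(S(=O)(=O)c3ccc(N)nc3)CC2)c1`: 40 mL.min-1.g-1

Within the data shown here, in an ADME assay (liver) for metabolic stability, with Liver microsome (Homo sapiens) as the target, using microsomes and NADPH, with a stated time of 30 min, tested at 1 uM (a lower number here means slower removal, a higher number faster removal of the compound), compound 2 gives 40 mL.min-1.g-1, the only true number so far. Compound 1 gives < 14 mL.min-1.g-1, which is a limit of the assay. Compound 3 `Nc1ccc(S(=O)(=O)N2CCN(c3ncc(C(O)(C(F)(F)F)C(F)(F)F)cc3-c3ccncc3)CC2)cn1` carries pyridin-4-yl in place of 3-(methanesulfonamido)phenyl on an aromatic carbon. Among the measured compounds shown here, the one measured step that bears on this is an at least 2.8-fold higher number from compound 1 to compound 2 (0.45 log units; beyond the scatter), beyond the scatter, where 3-(methanesulfonamido)phenyl replaced furan-3-yl. With that group gone again, the expected change is a fall, a 2.5-fold lower number from compound 2 to compound 3 (0.40 log units; beyond the scatter), although pyridin-4-yl is not furan-3-yl. For compound 3 the estimated value is 16 mL.min-1.g-1, with an expected range from 9 mL.min-1.g-1 to 35 mL.min-1.g-1.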

Compound 3, intrinsic clearance in microsomes: 15 mL.min-1.g-1
For compound 3 the middle estimate is 1.1-fold (0.03 log units) above the measured one, and the stated range covers the measured number.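

Replacing 3-(methanesulfonamido)phenyl with pyridin-4-yl gives a 2.7-fold lower number from compound 2 to compound 3 (0.43 log units; beyond the scatter) in this assay, so a six-membered aromatic ring at this position does not by itself bring the higher number of the earlier compound. Setting pyridin-4-yl against furan-3-yl gives an at least 1.0-fold higher number from compound 1 to compound 3 (0.02 log units; that floor lies within the scatter), so no order between these two groups can be read. The value of compound 1 is a limit: the limit of < 14 mL.min-1.g-1 in this assay, at which 1 of the 3 values shown sits.

As far as these compounds go, it remains open whether the higher number of compound 2 goes with the methanesulfonamido group or with the phenyl ring itself. A plain phenyl group at this position would separate the two.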